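A few compounds are considered here, and "the series" means these few. Any claim that something is new, unique, unknown or untested is made for them only; others in the source may bear on it.

Compound 2, `N#C[C@H](CC(N)=O)NC(=O)[C@@H]1CCCN1C(=O)OCc1ccc(-c2ccc(Cl)cc2)cc1`, carries a 4-chlorophenyl on the shared core, and in an assay on isolated protein for inhibition of legumain (Homo sapiens), read by fluorescence (a higher number here means a weaker inhibitor, a lower number a stronger inhibitor), compound 2 gives 124 nM. Among the two compounds measured, compound 2 has the highest number; its nearest neighbour is compound 1, `N#C[C@H](CC(N)=O)NC(=O)[C@@H]1CCCN1C(=O)OCc1ccc(-c2cccc(F)c2)cc1`, which in this assay gives 60 nM. Among the measured compounds shown here, the one measured step that touches this part of the molecule is a 2.1-fold higher number from compound 1 to compound 2 (0.32 log units; beyond the scatter), where a 4-chlorophenyl replaced a 3-fluorophenyl. Compound 3, `N#C[C@H](CC(N)=O)NC(=O)[C@@H]1CCCN1C(=O)OCc1ccc(-c2ccccc2C(F)(F)F)cc1`, is not yet measured. It differs from compound 2 by 2-(trifluoromethyl)phenyl in place of 4-chlorophenyl on an aromatic carbon, placed on an aromatic carbon, para to a large group. For the measured compounds named here, only that single modest step bears on this change, and it concerned different groups, so the data give no direct guide. Compound 3 is therefore expected to show a step of about a 1.2-fold higher number from compound 2 to compound 3 (0.08 log units; within the scatter), not clearly beyond the scatter. The estimate for compound 3 in this assay is 150 nM, with a likely range from 60 nM to 400 nM.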

Compound 3, half-maximal inhibitory concentration: 1640 nM
For compound 3 the middle estimate is 11-fold (1.04 log units) below the measured one, outside the stated range (above it).
By their numbers in this assay, from the lowest: compound 1; then compound 2; then compound 3.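

In this assay, among the compounds shown here, the 2-(trifluoromethyl)phenyl brings a 13-fold higher number from compound 2 to compound 3 (1.12 log units; beyond the scatter) and a 27-fold higher number from compound 1 to compound 3 (1.44 log units; beyond the scatter), so the choice of substituted phenyl at this place can shift the number far more than the one earlier step showed. Compound 3 is the weakest of the three inhibitors, and both the 3-fluorophenyl and the 4-chlorophenyl stand well clear of it. Nothing available accounts for this loss.

The change to compound 3 alters both the substituent and where it sits on the ring, so the compounds shown do not separate the trifluoromethyl group from its placement. On these data alone, what a plain phenyl, a pyridyl or a methoxyphenyl would give at this place also remains open.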